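A few compounds are considered here, and "the series" means these few. Any claim that something is new, unique, unknown or untested is made for them only; others in the source may bear on it.

Compound 3, `COc1ccc(S(C)(=O)=O)cc1C(=O)Nc1cccc(-c2nncn2C(C)C)n1`, gives 0% in an assay for inhibition of Ephrin type-A receptor 2 (Homo sapiens), tested at 1 uM; on this read-out lower numbers stand for less inhibition and higher numbers for more inhibition at the one concentration tested (going by the name of the read-out). Compound 1, `COc1ccc(S(N)(=O)=O)cc1C(=O)Nc1cccc(-c2nncn2C(C)C)n1`, gives 0% in this assay, and compound 2, `COc1cc(C)c(S(N)(=O)=O)cc1C(=O)Nc1cccc(-c2nncn2C(C)C)n1`, gives -1%. On these numbers compound 3 stands level with compound 1 at the digits printed; its nearest neighbour is compound 1, with no change at the digits printed between them, and its furthest is compound 2, though the gap between them is still within the scatter. All three numbers lie close to zero.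

Compound 4, `COc1cc(C)c(S(C)(=O)=O)cc1C(=O)Nc1cccc(-c2nncn2C(C)C)n1`, differs from compound 3 by a single change: methyl in place of hydrogen on an aromatic carbon. Among the compounds with values here, the one measured step that bears on this change is the same exchange on the same core, from compound 1 to compound 2, which gave a number 1 percentage points lower from compound 1 to compound 2 (within the scatter), a step within the scatter. Compound 3 already sits at the floor of the read-out, so the expected step is no change at the digits printed from compound 3 to compound 4 (within the scatter), none beyond the scatter. Compound 4 is therefore estimated at 0%, in a range from -10% to 10%.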

Compound 4, a percentage reported as inhibition, at one concentration (the size of the read-out at that concentration, not a potency): 0%
For compound 4 middle estimate and measured number coincide at the digits printed; the measured number falls inside the stated range.
By their numbers in this assay, from the lowest: compounds 2, 1, 3 and 4 (each within the scatter of the next).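

In this assay, methyl in place of hydrogen on the aromatic carbon ortho to a methylsulfonyl group gives no change at the digits printed from compound 3 to compound 4 (within the scatter), so the change now reads alike on a second core: the same change on two cores in this assay, a number 1 percentage points lower (within the scatter) from compound 1 to compound 2 and no change at the digits printed (within the scatter) from compound 3 to compound 4, 1 percentage points apart, within the scatter of two such steps. Methyl in place of amino on the sulfonyl sulfur, now read with the aromatic methyl present, gives a number 1 percentage points higher from compound 2 to compound 4 (within the scatter), and this change also reads alike on both cores: the same change on two cores in this assay, no change at the digits printed (within the scatter) from compound 1 to compound 3 and a number 1 percentage points higher (within the scatter) from compound 2 to compound 4, 1 percentage points apart, within the scatter of two such steps. Neither change moves the number beyond the scatter on either core.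

The compounds shown leave open whether another group at this position, such as an amine, a carboxylic acid or a longer chain, would move the number beyond the scatter. With every number close to zero, they also cannot tell how either change would read at any other concentration.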